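A Chlorine Swap at the Benzyl End of the Molecule

This account rests on a few compounds, and the source may have more. Where it says the series, first, only, none or still open, it means among the compounds named here.

Of the compounds shown here, two that share one core have been measured so far in a functional assay, read by spectrophotometry, with a stated time of 30 min; on this read-out lower numbers stand for stronger inhibition and higher numbers for weaker inhibition. Compound 1 `CC(C)(C)c1cc(/C=C/C(=O)NCCC2CCN(Cc3ccccc3)CC2)cc(C(C)(C)C)c1O` gives 81700 nM, and compound 2 `CC(C)(C)c1cc(/C=C/C(=O)NCCC2CCN(Cc3ccc(F)c(F)c3)CC2)cc(C(C)(C)C)c1O` gives 65700 nM. These two numbers lie within the scatter of each other, so compound 2 stands level with compound 1, and repeated measurements alone could produce a gap of this size.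

The next compound to be tested is compound 3 `CC(C)(C)c1cc(/C=C/C(=O)NCCC2CCN(Cc3cccc(Cl)c3)CC2)cc(C(C)(C)C)c1O`. It differs from compound 2 in one place: 3-chlorophenyl in place of 3,4-difluorophenyl on a saturated chain carbon bound to an amine nitrogen in a ring. In plain terms, 3-chlorophenyl sits in place of 3,4-difluorophenyl on a saturated chain carbon bound to an amine nitrogen in a ring.

Going by the values given here, only one measured step bears on this spot: a 1.2-fold lower number from compound 1 to compound 2 (0.09 log units; within the scatter). Among the compounds with values here, no compound carrying chlorine has been measured yet, so this small step is a thin guide. On that evidence, no step beyond the scatter is expected in this assay. The estimated change is a 1.1-fold higher number from compound 2 to compound 3 (0.03 log units; within the scatter). For compound 3 the expected value is 70000 nM, with an estimated range of 35000 nM to 140000 nM.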

Compound 3, half-maximal inhibitory concentration: 83100 nM
Beside the measured number, compound 3's estimate is 1.2-fold (0.07 log units) below it, and the stated range covers the measured number.
By their numbers in this assay, from the lowest: compounds 2, 1 and 3 (each within the scatter of the next).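

The piece now holds its first reading of chlorine at this spot: chloro in place of hydrogen on an aromatic carbon gives a 1.0-fold higher number from compound 1 to compound 3 (0.01 log units; within the scatter) in this assay and so leaves the number level with that of the plain phenyl compound. The direct exchange of 3,4-difluorophenyl for 3-chlorophenyl, on a saturated chain carbon bound to an amine nitrogen in a ring, gives a 1.3-fold higher number from compound 2 to compound 3 (0.10 log units; within the scatter) and is also too small to count as a real difference. With these two steps added to the earlier one, the plain phenyl, the two fluorines and the single chlorine cannot be told apart on this read-out, and no supporting measurement is available to explain why the three compounds read alike.

From the compounds shown here alone, all three groups on this ring are either unsubstituted or carry halogen, so it remains open whether a methoxy group, an amine or a carboxylic acid there would produce a step beyond the scatter. Also open, going by these compounds, is whether a longer chain in place of the saturated carbon that carries the ring would move the number in either direction.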